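Removing the ring methyl from compound 1: what to expect

This account rests on a few compounds, and the source may have more. Where it says the series, first, only, none or still open, it means among the compounds named here.

Measured so far:
Compound 1 `C[C@@H]1Cn2c(nnc2C(F)(F)F)CN1C(=O)c1cccc(Cc2n[nH]c(=O)c3ccccc23)c1` gives 1.5 10^-6 cm/s in an ADME assay on Caco-2 cells (Homo sapiens) for permeability, read by LC-MS, with a stated time of 2 h, at pH 7.4, tested at 10 uM; on this read-out lower numbers stand for lower permeability and higher numbers for higher permeability.
Compound 2 `C[C@@H]1Cn2c(nnc2C(F)(F)F)CN1C(=O)c1cccc(C(F)(F)c2n[nH]c(=O)c3ccccc23)c1` gives 7.9 10^-6 cm/s in this assay.
Compound 3 `C[C@H]1Cn2c(nnc2C(F)(F)F)CN1C(=O)c1cccc(C(F)(F)c2n[nH]c(=O)c3ccccc23)c1` gives 6.7 10^-6 cm/s in this assay.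

Among these three, compound 1 stands lowest; its gaps to compound 2 and compound 3 both lie beyond the scatter. Compound 4 `O=C(c1cccc(Cc2n[nH]c(=O)c3ccccc23)c1)N1CCn2c(nnc2C(F)(F)F)C1` differs from compound 1 by hydrogen in place of methyl on a saturated ring carbon. Going by the values given here, the only measured step, a 1.2-fold lower number from compound 2 to compound 3 (0.07 log units; within the scatter), concerns a change of configuration alone the fact that compounds 2 and 3 differ only in the configuration as drawn and so says nothing about removing a methyl group. Among the compounds with values here, no measured step therefore bears on this change, and no step beyond the scatter is expected for compound 4, with no change at the digits printed from compound 1 to compound 4 (within the scatter). Compound 4 is estimated at 1.5 10^-6 cm/s, within the range 0.6 10^-6 cm/s to 4 10^-6 cm/s.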

Compound 4, apparent permeability: 1.3 10^-6 cm/s
Compound 4: the middle estimate sits 1.2-fold (0.06 log units) above what was measured, within the range that was stated.
By their numbers in this assay, from the lowest: compounds 4 and 1 (each within the scatter of the next); then compounds 3 and 2 (each within the scatter of the next).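

Hydrogen in place of methyl on this saturated ring carbon gives a 1.2-fold lower number from compound 1 to compound 4 (0.06 log units; within the scatter) in this assay. Compound 2 and compound 3 showed only that the drawn configuration at this carbon could differ within the scatter; this pair shows that, on the core of compound 1, the methyl itself can be absent with no step beyond the scatter. Nothing on record explains this result.

From the compounds shown here alone, whether an ethyl group or an amine on this carbon would also stay within the scatter remains open. So does whether the same exchange of methyl for hydrogen would do so on the fluorinated core of compound 2.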